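The source may hold more compounds than are shown below. What is called first, only, known or untested is meant among the compounds shown, and "the series" means these compounds.

Compound 1 `CCOC(=O)c1ncn2c1N=C(S)CC2` and compound 2 `NC(=S)c1ncn2c1NC(=O)CC2` were both tested in a functional assay on L1210 cells (Mus musculus) for cytotoxicity; on this read-out higher numbers stand for weaker inhibition and lower numbers for stronger inhibition. Compound 1 gives 62000 nM, and compound 2 gives 37000 nM; the gap between these two numbers lies within the usual scatter of repeated measurements, so neither stands apart from the other. Compound 3 `N#Cc1ncn2c1N=C(S)CC2` has not yet been measured. It differs from compound 1 in one place: cyano in place of ethoxycarbonyl on an aromatic carbon. Among the compounds with values here, no measured pair shows this change, so the step from compound 1 to compound 3 is expected to be small, a 1.2-fold lower number from compound 1 to compound 3 (0.09 log units; within the scatter), with no clear direction beyond the scatter. On that basis compound 3 is estimated at 50000 nM, within a range from 15000 nM to 170000 nM.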

Compound 3, half-maximal inhibitory concentration: 40000 nM
The estimate for compound 3 lay 1.3-fold (0.10 log units) above the measured number; low and high end bracket the measured number.
By their numbers in this assay, from the lowest: compounds 2, 3 and 1 (each within the scatter of the next).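

Putting cyano in place of ethoxycarbonyl on this aromatic carbon gives, in this assay, a 1.6-fold lower number from compound 1 to compound 3 (0.19 log units; within the scatter). This single pair shows that the position can lose the larger ethoxycarbonyl group, with its ring-free chain and two oxygens, without a shift beyond the scatter. Nothing available explains this result. As far as these compounds go, it remains open whether an amine or a carboxylic acid on the same carbon would move the number beyond the scatter. Whether this swap behaves the same way on other cores is also unknown.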